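The source may report more compounds than this note shows. Statements on the series, on what has been measured and on what is new or still open speak of the compounds shown alone.

Of the compounds shown here, three sharing one core have been measured in a functional assay on HT-29 cells (Homo sapiens) for cytotoxicity, read by sulforhodamine B assay; on this read-out higher numbers stand for weaker inhibition of growth and lower numbers for stronger inhibition of growth. Compound 1 `CC1=CC[C@@H]([C@@](C)(O)CCCC(C)(C)NC=S)CC1` carries a thiocarbonyl on the amine and gives 11400 nM. Compound 2 `CC1=CC[C@@H]([C@@](C)(O)CCCC(C)(C)NC(=S)N/N=C\c2ccc(C)cc2)CC1` extends this into a thiosemicarbazone bearing a 4-methylphenyl group and gives 10400 nM. Compound 3 `CC1=CC[C@@H]([C@@](C)(O)CCCC(C)(C)NC(=S)N/N=C\c2ccc(O)cc2)CC1` is its 4-hydroxyphenyl counterpart and gives 8150 nM. Within the data shown here, compound 3 shows the lowest of the three numbers, yet the step of a 1.3-fold lower number from compound 2 to compound 3 (0.11 log units; within the scatter) and the gap to compound 1 both lie within the scatter, so no compound can be called more or less potent than another on this evidence.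

Compound 4 `CC1=CC[C@@H]([C@@](C)(O)CCCC(C)(C)NC(=S)N/N=C\c2ccccc2Cl)CC1` has not been measured. It differs from compound 3 by 2-chlorophenyl in place of 4-hydroxyphenyl on a carbon with a double bond to nitrogen. Among the measured compounds shown here, the only measured step of comparable kind is the swap of substituents on the same aromatic ring, a 1.3-fold lower number from compound 2 to compound 3 (0.11 log units; within the scatter), which stayed within the scatter. On that basis the expected step of a 1.0-fold higher number from compound 3 to compound 4 (0.02 log units; within the scatter) is small and without a clear direction. Compound 4 is therefore expected to give about 8500 nM, with a likely range from 3000 nM to 24000 nM in this assay.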

Compound 4, concentration for 50% growth inhibition: 23700 nM
Beside the measured number, compound 4's estimate is 2.8-fold (0.45 log units) below it; the range from low to high includes it.
By their numbers in this assay, from the lowest: compounds 3, 2 and 1 (each within the scatter of the next); then compound 4.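

Swapping the aryl group on a carbon with a double bond to nitrogen can move the number beyond the scatter in this assay: 2-chlorophenyl in place of 4-hydroxyphenyl gives a 2.9-fold higher number from compound 3 to compound 4 (0.46 log units; beyond the scatter) and 2-chlorophenyl in place of 4-methylphenyl gives a 2.3-fold higher number from compound 2 to compound 4 (0.36 log units; beyond the scatter) as the matching step. Among these compounds, the earlier swap on this ring stayed within the scatter, so these are the first modest but readable changes at this position, and both run toward weaker inhibition of growth. Nothing measured here speaks to the reason for this change.

From the compounds shown here alone, it remains open whether the chlorine itself or its place on the ring accounts for the step, and a 4-chlorophenyl group would separate the two. Going by these compounds, how a 4-methoxyphenyl or a 4-aminophenyl group would read here also remains open.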